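Arylsulfonamide series: 3-chlorophenyl in place of 4-methylphenyl

The source may report more compounds than this note shows. Statements on the series, on what has been measured and on what is new or still open speak of the compounds shown alone.

Measured compounds:
compound 1 `Cc1ccc(S(=O)(=O)NC2=NCCN2C(=S)SN2CCn3c2nsc3=S)cc1`, in a functional assay on KYSE-510 cells (Homo sapiens) for antiproliferative activity, read by crystal violet staining, with a stated time of 96 h (a higher number here means a weaker inhibitor of growth, a lower number a stronger inhibitor of growth), compound 1 gives >= 20000 nM, which is a limit of the assay and not a number.
compound 2 `O=S(=O)(NC1=NCCN1C(=S)SN1CCn2c1nsc2=S)c1ccc(Br)cc1`, in this assay compound 2 gives >= 20000 nM, again a limit.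
compound 3 `O=S(=O)(NC1=NCCN1C(=S)SN1CCn2c1nsc2=S)c1ccccc1Cl`, in this assay compound 3 gives >= 20000 nM, again a limit.

Compound 1 therefore stands only at a limit, with no number to place it against the others; the same holds across the set, since (the limit of >= 20000 nM in this assay, at which 3 of the 3 values shown sit). The changes among the measured compounds, a step that the two limits leave unreadable from compound 1 to compound 2, a step that the two limits leave unreadable from compound 1 to compound 3 and a step that the two limits leave unreadable from compound 2 to compound 3, are all left unreadable by the two limits, so no size or direction can be drawn from them.

Compound 4 `O=S(=O)(NC1=NCCN1C(=S)SN1CCn2c1nsc2=S)c1cccc(Cl)c1` differs from compound 1 by 3-chlorophenyl in place of 4-methylphenyl on a sulfonyl sulfur. Within the data shown here, the steps that bear on this change are those bringing in a chlorophenyl, from compound 1 to compound 3 and from compound 2 to compound 3, and both are unreadable. No step beyond the scatter can be expected in this assay in either direction; the estimated step is a step that the limit leaves unreadable from compound 1 to compound 4, most likely as another limit. Compound 4 is estimated at 25000 nM, expected between 10000 nM and 80000 nM.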

Compound 4, concentration for 50% growth inhibition: >= 20000 nM
Compound 4: no number, only a limit; the forecaster's own chance of this, stated with the estimate: 85%; the middle value lies beyond the limit too.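

In this assay compound 4 gives >= 20000 nM, a limit and not a number. Among these compounds, no step from compound 1, compound 2 or compound 3 to compound 4 can be read: the limit of >= 20000 nM in this assay, at which 4 of the 4 values shown sit. The compounds shown leave open how strongly any of them inhibits growth, and whether changing the aryl group on the sulfonyl sulfur alters that.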